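This account rests on a few compounds, and the source may have more. Where it says the series, first, only, none or still open, it means among the compounds named here.

In an ADME assay on MDBK cells (Bos taurus) for cytotoxicity, read by MTT assay, with a stated time of 96 h (a lower number here means that less compound is tolerated, a higher number that more compound is tolerated), compound 3 (`C/C(=N\NC(N)=O)c1ccc2[nH]c(-c3ccccc3)nc2c1`) reads > 100000 nM and this is a limit of the assay, not a number. Compound 1 (`CC(=O)c1ccc2[nH]c(-c3ccc(Cl)cc3)nc2c1`) reads > 100000 nM and this too is a limit. Compound 2 (`C/C(=N\O)c1ccc2[nH]c(-c3ccc(Cl)cc3)nc2c1`) gives 37000 nM as an actual number. Compound 3 thus stands at the limit of > 100000 nM in this assay, at which 2 of the 3 values shown sit, with no number to step from.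

Compound 4 (`C/C(=N\NC(N)=O)c1ccc2[nH]c(-c3ccc(Cl)cc3)nc2c1`) has chloro in place of hydrogen on an aromatic carbon, para to a large group, which turns phenyl into 4-chlorophenyl (chloro in place of hydrogen on an aromatic carbon). Within the data shown here, no measured step makes this same change. Among the measured compounds shown here, the only measured step is an at least 2.7-fold lower number from compound 1 to compound 2 (0.43 log units; beyond the scatter) and it alters a different group while 4-chlorophenyl stays in place, so it bears on compound 4 only indirectly. It does show, through compound 2, that a compound with 4-chlorophenyl can fall short of the limit, while compound 1 shows that one can also stay there. In this assay a modest step towards lower numbers is therefore expected, or none that can be seen. The expected change is an at least 1.3-fold lower number from compound 3 to compound 4 (0.12 log units; that floor lies within the scatter) and it starts from a limit only. The estimate for compound 4 is 75000 nM with an expected range from 30000 nM to 150000 nM and a fair chance of a limit instead of a number.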

Compound 4, half-maximal cytotoxic concentration: > 100000 nM
Compound 4: a limit, no number; the forecaster's own chance of this, stated with the estimate: 55%; middle value at least 1.3-fold (0.12 log units) away from the limit.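

In this assay, compound 4 reads > 100000 nM, and this is a limit, so the change of phenyl to 4-chlorophenyl, para to a large group, does not yield a readable number here. The steps to compound 4 from compound 3 and from compound 1 have limits at both ends and cannot be read, so the size of any effect of chloro stays hidden: the limit of > 100000 nM in this assay, at which 3 of the 4 values shown sit. Among these compounds, what compound 4 adds is a comparison with 4-chlorophenyl held in place, an at least 2.7-fold higher number from compound 2 to compound 4 (0.43 log units; beyond the scatter), with ureido in place of hydroxy on the double-bonded nitrogen, which leaves compound 2 as the only one of the compounds carrying 4-chlorophenyl to give an actual number.

Going by these compounds, how far compound 1, compound 3 and compound 4 each lie past the limit remains unknown, and so does whether chloro changes anything at all at this place when ureido is present. Also open, on these data alone, is whether methoxy or a carboxylic acid in place of chloro, or an amine in place of ureido on the double-bonded nitrogen, would bring a compound with this core down to a readable number.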